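This account rests on a few compounds, and the source may have more. Where it says the series, first, only, none or still open, it means among the compounds named here.

Of the compounds shown here, three have been measured in a functional assay on MCF7 cells (Homo sapiens) for antiproliferative activity, read by MTT assay, with a stated time of 72 h; a higher number here means a weaker inhibitor, a lower number a stronger inhibitor. Compound 1 `CCN1CCN(c2cc(C)c3cc(NC(=O)c4ccc(Cl)cc4)ccc3n2)CC1` gives 1530 nM. Compound 2 `CCN1CCN(c2cc(C)c3cc(NC(=O)c4ccc5ccccc5n4)ccc3n2)CC1` gives 7060 nM. Compound 3 `CCN1CCN(c2cc(C)c3cc(NC(=O)c4ccco4)ccc3n2)CC1` gives 41200 nM, the highest of the three numbers; the steps of a 27-fold higher number from compound 1 to compound 3 (1.43 log units; beyond the scatter) and a 5.8-fold higher number from compound 2 to compound 3 (0.77 log units; beyond the scatter) both run toward weaker inhibition, while a 4.6-fold higher number from compound 1 to compound 2 (0.66 log units; beyond the scatter) is modest. Compound 4 `CCN1CCN(c2cc(C)c3cc(NC(=O)c4ccc[nH]4)ccc3n2)CC1` differs from compound 3 in one place: 1H-pyrrol-2-yl in place of furan-2-yl on a carbonyl carbon. Going by the values given here, no measured step exchanges one five-membered aromatic ring for another, so none bears on this change directly; what can be said is that compound 3 already stands at the weak end. The step expected here is a 1.4-fold lower number from compound 3 to compound 4 (0.14 log units; within the scatter), with no firm direction beyond the scatter. Compound 4 is estimated at 30000 nM, in a range from 10000 nM to 90000 nM.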

Compound 4, half-maximal inhibitory concentration: 14700 nM
For compound 4 the middle estimate is 2.0-fold (0.31 log units) above the measured one; low and high end bracket the measured number.
By their numbers in this assay, from the lowest: compound 1; then compound 2; then compound 4; then compound 3.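

The carbonyl position responds even to an exchange of one five-membered aromatic ring for another: in this assay there is a 2.8-fold lower number from compound 3 to compound 4 (0.45 log units; beyond the scatter), with a hydrogen-bond donor entering and a hydrogen-bond acceptor leaving. The 1H-pyrrol-2-yl group still falls short of the larger groups, with a 2.1-fold higher number from compound 2 to compound 4 (0.32 log units; beyond the scatter) and a 9.6-fold higher number from compound 1 to compound 4 (0.98 log units; beyond the scatter), so the five-membered rings remain the two highest numbers of the series. Nothing measured accounts for the difference between the two rings.

From the compounds shown here alone, whether the hydrogen-bond donor matters remains open. So does the place of thiophen-2-yl, which has neither the ring nitrogen nor the ring oxygen, relative to these two rings.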